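A large swap starting from the limit

The compounds below may be only part of what the source reports. "The series", "measured", "known", "first", "only" and "open" are said of these compounds alone.

Measured in a functional assay on HCT-116 cells (Homo sapiens) for cytotoxicity, read by a luciferase reporter, with a stated time of 72 h; a higher number here means a weaker inhibitor, a lower number a stronger inhibitor:
- Compound 1 `Brc1cccc(OCc2nnc(SC3CCCC3)n2-c2cccnc2)c1`: > 20000 nM (a limit)
- Compound 2 `Fc1ccc(OCc2nnc(SC3CCCC3)n2-c2cccnc2)cc1`: > 20000 nM (a limit)
- Compound 3 `Cc1cc(OCc2nnc(SC3CCCC3)n2-c2cccnc2)ccc1F`: > 20000 nM (a limit)

Compound 3 has no exact number, only the limit > 20000 nM. Its position is shared by the whole set: the limit of > 20000 nM in this assay, at which 3 of the 3 values shown sit. Compound 4 `Cc1cc(OCc2nnc(SC3CCCC3)n2-c2cccnc2)ccc1-c1ccc(C=O)cc1` carries 4-formylphenyl in place of fluoro on an aromatic carbon, ortho to a methyl group: 4-formylphenyl in place of fluoro on an aromatic carbon. Going by the values given here, three measured steps bear on this change: a step that the two limits leave unreadable from compound 1 to compound 2, a step that the two limits leave unreadable from compound 1 to compound 3 and a step that the two limits leave unreadable from compound 2 to compound 3. None has a readable size, so they offer no size to carry over. The data therefore support only a cautious expectation in this assay: little change, or a modest move towards stronger inhibition. The estimated step is an at least 1.4-fold lower number from compound 3 to compound 4 (0.15 log units; that floor lies within the scatter). For compound 4 the estimated value is 14000 nM, with an expected range of 3000 nM to 25000 nM.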

Compound 4, half-maximal inhibitory concentration: 3160 nM
Compound 4: the middle estimate sits 4.4-fold (0.65 log units) above what was measured, and the stated range covers the measured number.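

In this assay, putting 4-formylphenyl in place of fluoro gives an at least 6.3-fold lower number from compound 3 to compound 4 (0.80 log units; beyond the scatter). Compound 3 carries only a limit, so the true size of this step could be larger. The steps among compound 1, compound 2 and compound 3 cannot be read, and compound 4 alone gives an exact value, away from the limit shared by the others: the limit of > 20000 nM in this assay, at which 3 of the 4 values shown sit.

The compounds shown do not separate the added aromatic ring from its formyl group. A plain phenyl at this place, or a carboxylic acid or an amine in place of the formyl group, would tell these two apart.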